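Ester variation on a shared core, antiproliferative read-out

The source may report more compounds than this note shows. Statements on the series, on what has been measured and on what is new or still open speak of the compounds shown alone.

Measured compounds:
- compound 1 `C/C=C1/[C@H](O[C@@H]2O[C@H](CO)[C@@H](O)[C@H](O)[C@H]2O)OC=C(C(=O)OC)[C@H]1CC(=O)OCc1ccco1`; in a functional assay on SK-BR-3 cells (Homo sapiens) for antiproliferative activity, read by MTT assay, with a stated time of 72 h (on this read-out higher numbers stand for weaker inhibition and lower numbers for stronger inhibition), compound 1 reaches only the assay limit, > 15000 nM.
- compound 2 `C/C=C1/[C@H](O[C@@H]2O[C@H](COC(C)=O)[C@@H](OC(C)=O)[C@H](OC(C)=O)[C@H]2OC(C)=O)OC=C(C(=O)OC)[C@H]1CC(=O)OCCC1CCCCC1`; in this assay compound 2 reaches only the assay limit, > 15000 nM.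
- compound 3 `C/C=C1/[C@H](O[C@@H]2O[C@H](COC(C)=O)[C@@H](OC(C)=O)[C@H](OC(C)=O)[C@H]2OC(C)=O)OC=C(C(=O)OC)[C@H]1CC(=O)OCCC(C)C`; in this assay compound 3 reaches only the assay limit, > 15000 nM.

Compound 1 therefore stands at the limit, and so do the other two members of the set, as the limit of > 15000 nM in this assay, at which 3 of the 3 values shown sit, records. No numerical value is available for any of them. Among the measured compounds shown here, the single one-point step in the set, a step that the two limits leave unreadable from compound 2 to compound 3, is unreadable for the same reason: both ends sit at the limit, so its size cannot be taken from the data.

Compound 4 `C/C=C1/[C@H](O[C@@H]2O[C@H](CO)[C@@H](O)[C@H](O)[C@H]2O)OC=C(C(=O)OC)[C@H]1CC(=O)OC` is the next member to be measured. It differs from compound 1 by hydrogen in place of furan-2-yl on a saturated chain carbon bound to an oxygen next to a carbonyl group. For the measured compounds named here, no measured step touches this position, and the only measured step available, from compound 2 to compound 3, gives no readable size, so the evidence offers no direction for a change in this assay. The expectation is that compound 4 will again be reported at the limit, with a step that the limit leaves unreadable from compound 1 to compound 4 expected to be no readable step. The estimate for compound 4 is 20000 nM, within 8000 nM to 60000 nM.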

Compound 4, half-maximal inhibitory concentration: > 15000 nM
Compound 4 was reported as a limit (the forecaster's own chance of this, stated with the estimate: 85%); the middle value lies beyond the limit too.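

No step can be read between compound 1 and compound 4, as both results are limits and not numbers, and the whole set shares a single limit: the limit of > 15000 nM in this assay, at which 4 of the 4 values shown sit.

The compounds shown leave open whether any ester variation on the shared core gives a measurable value in this assay, and how large any such change would be.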